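The source may hold more compounds than are shown below. What is called first, only, known or untested is meant among the compounds shown, and "the series" means these compounds.

Compound 1 `COCCNC(=O)c1cc2cccc(OC)c2oc1=N` is tested in an assay on CHO cells for displacement of a labelled ligand from adenosine receptor A1 (Homo sapiens), read by scintillation counting, with a stated time of 60 min, tested at 10 uM; a higher number here means more inhibition at the concentration tested (going by the name of the read-out), a lower number less inhibition. In this assay compound 1 gives > 70%, which is a limit of the assay rather than a number. Compound 2 `COCCNC(=O)c1cc2cccc(OC)c2oc1=O` gives 45% in this assay. Among the values shown, compound 1 sits at the limit, as noted in the limit of > 70% in this assay, at which 1 of the 2 values shown sits. The step to compound 3 `COc1cccc2cc(C(=O)NC3CCCC3)c(=N)oc12` is cyclopentyl in place of 2-methoxyethyl on an amide-type nitrogen. For the measured compounds named here, with no measured step of this kind to go by, the change is expected to fall within the scatter, giving an expected step that the limit leaves unreadable from compound 1 to compound 3 from compound 1 to compound 3. Compound 3 is estimated at 75%, with a range from 50% to 95%.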

Compound 3, a percentage reported as inhibition, at one concentration (the size of the read-out at that concentration, not a potency): > 70%
Compound 3: only a limit was reported; the forecaster's own chance of this, stated with the estimate: 60%; the middle value lies beyond the limit too.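

Compound 1 and compound 3 both sit at a limit of the read-out in this assay, so the step between them cannot be read: the limit of > 70% in this assay, at which 2 of the 3 values shown sit.

The compounds shown leave open how cyclopentyl and 2-methoxyethyl on the amide-type nitrogen compare in inhibition.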